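Anilino in place of benzyl: notes on compound 3

The source may hold more compounds than are shown below. What is called first, only, known or untested is meant among the compounds shown, and "the series" means these compounds.

Compound 1 `O=C(Oc1ccc(OCc2ccccc2)cc1)N(Cc1ccccc1)S(=O)(=O)c1ccc(Cl)cc1`: > 100%
Compound 2 `O=C(Nc1ccc(OCCCCc2ccccc2)cc1)N(Cc1ccccc1)S(=O)(=O)c1ccc(Cl)cc1`: 45%

In an ADME assay on a cell-free system (plasma, Homo sapiens) for metabolic stability, read by HPLC, with a stated time of 30 min, tested at 10 uM (on this read-out higher numbers stand for a more stable compound and lower numbers for a less stable compound), compound 1 gives > 100%, which is a limit of the assay and not a number. Compound 3 `O=C(Oc1ccc(OCc2ccccc2)cc1)N(Nc1ccccc1)S(=O)(=O)c1ccc(Cl)cc1` carries anilino in place of benzyl on an amide-type nitrogen. Within the data shown here, no measured pair isolates this change, so the expectation is loose. Compound 2 gives 45%, which shows that a compound of this series can be lost in this assay. The expected step of a number at least 15 percentage points lower from compound 1 to compound 3 (beyond the scatter) is a modest fall, possibly no larger than the scatter. For compound 3 the estimate is 85%, with an expected range of 55% to 105%.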

Compound 3, percent of the compound remaining: < 1%
Compound 3: only a limit was reported (the forecaster's own chance of this, stated with the estimate: 20%); middle value at least 84 percentage points from the limit.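

In this assay, among these compounds, anilino in place of benzyl on this amide-type nitrogen gives a number at least 99 percentage points lower from compound 1 to compound 3 (beyond the scatter), the first change at this position that a measured pair isolates, and it is large. Compound 3 stands at a limit of the assay: the limit of < 1% in this assay, at which 1 of the 3 values shown sits.
Compound 1 also stands at a limit, so the true size of the step stays unknown: the limit of > 100% in this assay, at which 1 of the 3 values shown sits.

The compounds shown leave open whether this fall needs the aromatic ring of anilino or only the nitrogen that joins it. A plain amino or a methylamino group at this position would separate the two.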